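A Smaller Ring on the Side Chain of Compound 2

This account rests on a few compounds, and the source may have more. Where it says the series, first, only, none or still open, it means among the compounds named here.

- compound 1 `O=C(N/N=C/c1ccc(O)cc1Br)Nc1ccc(Oc2ccnc3[nH]ccc23)cc1` gives "not active" (no number reported) without a figure
- compound 2 `O=C(N/N=C/c1cccn1CCCN1CCCCC1)Nc1ccc(Oc2ccnc3[nH]ccc23)c(F)c1` gives 2840 nM as its value

Within the data shown here, in a functional assay on PC-3 cells (Homo sapiens) for antiproliferative activity, read by MTT assay, with a stated time of 72 h (on this read-out higher numbers stand for weaker inhibition and lower numbers for stronger inhibition), compound 2 carries the only number available, 2840 nM and there is nothing numerical to rank it against. Compound 1 is recorded as "not active" (no number reported) with no figure attached.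

The next compound to be tested is compound 3 `O=C(N/N=C/c1cccn1CCCN1CCCC1)Nc1ccc(Oc2ccnc3[nH]ccc23)c(F)c1` and it keeps the rest of compound 2 unchanged. The change is pyrrolidin-1-yl in place of piperidin-1-yl on a saturated chain carbon, three bonds along the chain from an aromatic nitrogen and it turns the 3-(piperidin-1-yl)propyl into 3-(pyrrolidin-1-yl)propyl, so pyrrolidin-1-yl stands in place of piperidin-1-yl on a saturated chain carbon, three bonds along the chain from an aromatic nitrogen.

Among the measured compounds shown here, no pair of measured compounds shows what this exchange does, so the expectation rests only on compound 2 at 2840 nM as its starting point. No step beyond the usual scatter is expected in this assay and no direction is firmly favoured. The expected move is a 1.1-fold lower number from compound 2 to compound 3 (0.04 log units; within the scatter) and it is estimated to stay small. For compound 3 the expected value is 2600 nM with an estimated range from 1000 nM to 6500 nM as the likely span.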

Compound 3, half-maximal inhibitory concentration: 3580 nM
Compound 3: middle estimate off by 1.4-fold (0.14 log units), on the low side; the range from low to high includes it.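

In this assay the side chain now has its first measured exchange: pyrrolidin-1-yl in place of piperidin-1-yl, on a saturated chain carbon, three bonds along the chain from an aromatic nitrogen, comes with a 1.3-fold higher number from compound 2 to compound 3 (0.10 log units; within the scatter) and so leaves the two compounds without an order. At this position, in this read-out, the five-membered non-aromatic ring and the six-membered one therefore cannot be told apart, something the lone figure for compound 2 could not show. Nothing measured on these compounds speaks to the reason for this result.

From the compounds shown here alone, whether a morpholin-4-yl ring or an open dimethylamino group on the same propyl chain, or a shorter 2-(pyrrolidin-1-yl)ethyl chain, would move the number beyond the scatter remains open, since one exchange of one ring for another marks out only a small part of what this position might accept. Among these compounds, compound 1 carries no figure and differs from the other compounds in more than one place, so no step involving it can be read.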